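Working notes on cytotoxicity: from compound 2 to compound 4

The source may hold more compounds than are shown below. What is called first, only, known or untested is meant among the compounds shown, and "the series" means these compounds.

Measured compounds:
compound 1 `Cc1cccc(-c2cccc(NCc3cncn3Cc3ccccc3)c2)c1C` — > 1000 nM
compound 2 `COC(=O)c1ccc(NCc2cncn2Cc2ccccc2-c2ccccc2)cc1-c1ccccc1` — "not determined" (no result reported)
compound 3 `CNC(=O)c1ccc(NCc2cncn2Cc2ccc(-c3ccccc3)cc2)cc1-c1ccccc1` — > 1000 nM

In a toxicity assay on NIH3T3 cells (Mus musculus) for cytotoxicity, read by resazurin assay (a lower number here means that less compound is needed, a higher number that more compound is needed for the effect), compound 1 gives > 1000 nM, which is a limit of the assay and not a number. Compound 3 gives > 1000 nM in this assay, again a limit rather than a number. Compound 2 has no result in this assay at all, only "not determined" (no result reported). Compound 2 therefore stands nowhere on the numbers shown; what the series offers is the limit of > 1000 nM in this assay, at which 2 of the 3 values shown sit, and nothing more.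

Compound 4 `COC(=O)c1ccc(NCc2cncn2Cc2ccccc2[N+](=O)[O-])cc1-c1ccccc1` differs from compound 2 by nitro in place of phenyl on an aromatic carbon. Cut one bond further out, the same difference reads 2-phenylphenyl to 2-nitrophenyl.

For the measured compounds named here, no measured step joins compound 2 and compound 4, and with compound 2 unmeasured the size of the step in this assay cannot be anchored at either end. The expectation rests on compound 1 and compound 3, both of which sit at a limit; no step beyond the scatter is expected in either direction, and the most likely outcome for compound 4 is again a limit. In this assay compound 4 is estimated at 2000 nM, with a range from 700 nM to 10000 nM.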

Compound 4, half-maximal effective concentration: 10000 nM
Compound 4: the middle estimate sits 5.0-fold (0.70 log units) below what was measured, and the stated range covers the measured number.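

For the compounds shown here, compound 2 has no number in this assay, so no step from it to compound 4 can be read, and compound 4 stands alone at 10000 nM. What the change from 2-phenylphenyl to 2-nitrophenyl does in this assay stays open, and the only other reference the series offers is a limit: the limit of > 1000 nM in this assay, at which 2 of the 4 values shown sit.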